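Phenyl in place of methylpyridyl on a saturated ring carbon

The source may report more compounds than this note shows. Statements on the series, on what has been measured and on what is new or still open speak of the compounds shown alone.

Compound 1 `O=C(CN1CCN(c2ccccn2)CC1)Nc1cccnc1`: 6410 nM
Compound 2 `Cc1ccc(C2CCN(CC(=O)Nc3cccc(C)c3)CC2)nc1`: 41.7 nM

Of the compounds shown here, two have been tested in an assay on HEK293 cells for displacement of a labelled ligand from D(4) dopamine receptor (Homo sapiens), read by scintillation counting, with a stated time of 60 min; on this read-out higher numbers stand for weaker inhibition and lower numbers for stronger inhibition. In this assay compound 1 gives 6410 nM, while compound 2 gives 41.7 nM. Compound 2 therefore holds the lowest number of the two, and the gap to compound 1 is far wider than the ordinary scatter of repeated measurements. The two compounds differ from each other in several places at once, so no single structural step can be read from that comparison.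

Compound 3 `Cc1cccc(NC(=O)CN2CCC(c3ccccc3)CC2)c1` is the next compound to be measured. It differs from compound 2 in one place only: phenyl in place of 5-methylpyridin-2-yl on a saturated ring carbon. The aromatic group on the saturated ring carbon becomes smaller and loses its ring nitrogen and its methyl. Among the measured compounds shown here, no measured pair shows a step of this kind, so the expectation rests on compound 2 alone. The change from compound 2 to compound 3 is expected to weaken binding slightly, by a 1.9-fold higher number from compound 2 to compound 3 (0.28 log units; within the scatter), a step close to the edge of the scatter. Compound 3 is accordingly estimated at 80 nM, with a plausible range from 15 nM to 500 nM.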

Compound 3, inhibition constant: 25.8 nM
Beside the measured number, compound 3's estimate is 3.1-fold (0.49 log units) above it, within the range that was stated.
By their numbers in this assay, from the lowest: compounds 3 and 2 (each within the scatter of the next); then compound 1.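

In this assay the exchange of 5-methylpyridin-2-yl for phenyl on the saturated ring carbon gives a 1.6-fold lower number from compound 2 to compound 3 (0.21 log units; within the scatter) and so leaves the two compounds indistinguishable on this read-out. This is the only comparison shown that differs in one place, and it indicates that, three ring bonds from the ring nitrogen, the aromatic group can lose both its ring nitrogen and its methyl together with no change in binding that this measurement can resolve. Nothing measured here explains why the two groups read alike.

Because the ring nitrogen and the methyl leave in the same step, this pair cannot separate what each contributes, and a pyridin-2-yl without the methyl or a tolyl ring would be needed to pull the two apart. Going by these compounds, how far this position tolerates other groups also remains open, for example a phenyl carrying a chlorine or a methoxy, a saturated cyclohexyl ring, or a carboxylic acid or an amine on the same ring carbon.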